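Nitro Substitution on a Coumarin-Isoxazole Cytotoxicity Series

The source may hold more compounds than are shown below. What is called first, only, known or untested is meant among the compounds shown, and "the series" means these compounds.

Measured compounds:
compound 1 `O=c1ccc2cc(OCc3cc(-c4ccccc4)no3)ccc2o1`, 53200 nM
compound 2 `O=c1ccc2cc(OCc3cc(-c4ccc5ccccc5c4)no3)ccc2o1`, "not determined" (no result reported)

Among the measured compounds shown here, compound 1 `O=c1ccc2cc(OCc3cc(-c4ccccc4)no3)ccc2o1` is the only compound with a number in a functional assay on PC-3 cells (Homo sapiens) for cytotoxicity, read by MTT assay, with a stated time of 48 h (on this read-out lower numbers stand for stronger inhibition and higher numbers for weaker inhibition), where compound 1 gives 53200 nM. Compound 2 `O=c1ccc2cc(OCc3cc(-c4ccc5ccccc5c4)no3)ccc2o1` was examined in the same way, but for compound 2 the entry reads "not determined" (no result reported), so it offers no comparison.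

The step from compound 1 to compound 3 `O=c1ccc2cc(OCc3cc(-c4ccccc4[N+](=O)[O-])no3)ccc2o1` is the change (nitro in place of hydrogen on an aromatic carbon). For the measured compounds named here, no step between two measured compounds is available to show how such a change behaves in this assay. The account therefore expects a small step from compound 1 to compound 3, if any, one that stays within the usual scatter, with the direction left open.

Compound 3 is expected to give 40000 nM in this assay, within a range of 15000 nM to 120000 nM, which means an estimated step of a 1.3-fold lower number from compound 1 to compound 3 (0.12 log units; within the scatter).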

Compound 3, half-maximal inhibitory concentration: 8200 nM
For compound 3 the middle estimate is 4.9-fold (0.69 log units) above the measured one; the measured number lies below the stated range.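

Replacing phenyl with 2-nitrophenyl gives a 6.5-fold lower number from compound 1 to compound 3 (0.81 log units; beyond the scatter) in this assay, so a change on this ring, at this place ortho to a large group, can move the number beyond the usual scatter. Among the compounds shown here, compound 2 carries no number, which makes this the only step so far that says anything about substitution on this ring, and it points towards stronger inhibition. Nothing available bears on why the number falls.

The compounds shown leave open whether this drop is specific to nitro or would also appear with an amine or a carboxylic acid at the same place. They also leave open whether nitro on another carbon of the ring would give a step of similar size and direction.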